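Vinyl for hydrogen on two cores: notes on compounds 1 to 4

The source may report more compounds than this note shows. Statements on the series, on what has been measured and on what is new or still open speak of the compounds shown alone.

Compound 1 `CCCCCCCC[C@@]1(C)SC(=O)C=C1OC` and compound 2 `C=CCOC1=CC(=O)S[C@]1(C)CCCCCCCC` share one core; compound 3 `C=CCC1(C)C(=O)S[C@](C)(CCCCCCCC)C1=O` and compound 4 `C=CCC1(CC=C)C(=O)S[C@](C)(CCCCCCCC)C1=O` share another. The difference between the two cores is not broken down here.

In a functional assay on MCF7 cells (Homo sapiens) for inhibition, read by radiometric assay and XTT assay (a lower number here means a stronger inhibitor, a higher number a weaker inhibitor), compound 1 gives 16.4 ug/mL. Compound 2 differs from compound 1 by a single change, (vinyl in place of hydrogen on a saturated chain carbon bound to an oxygen on an unsaturated carbon). In this assay compound 2 gives 14.5 ug/mL, and the step of a 1.1-fold lower number from compound 1 to compound 2 (0.05 log units; within the scatter) shows that this change left the read-out essentially unmoved.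

In this assay compound 3 gives 40.5 ug/mL. This is the highest of the three measured numbers, and its gap to compound 1 and to compound 2 lies beyond the scatter in both cases.

Compound 4 differs from compound 3 by vinyl in place of hydrogen on a saturated chain carbon bound to a saturated ring carbon. Among the measured compounds shown here, this is the same kind of change as the one from compound 1 to compound 2, not the same one: around the place, the saturated chain carbon is bound to a saturated ring carbon in compound 3, whereas in compound 1 it is bound to an oxygen on an unsaturated carbon. For the measured compounds named here, the only measured instance of this kind of change is a 1.1-fold lower number from compound 1 to compound 2 (0.05 log units; within the scatter), a step within the scatter, so the step from compound 3 to compound 4 is expected to be of similar size, a 1.1-fold lower number from compound 3 to compound 4 (0.03 log units; within the scatter), with the wider range allowing for the different surroundings of the place. Compound 4 is therefore expected to give about 38 ug/mL in this assay, with an expected range from 18 ug/mL to 80 ug/mL.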

Compound 4, half-maximal inhibitory concentration: 40.5 ug/mL
Beside the measured number, compound 4's estimate is 1.1-fold (0.03 log units) below it; measured number inside the range.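

In this assay, the step on the second core reads no change at the digits printed from compound 3 to compound 4 (within the scatter), so vinyl in place of hydrogen leaves the two numbers indistinguishable here, as it did on the first core. Set side by side, the two steps show that this change carries from one core to the other in this series without a difference that can be told from the scatter: the same change on two cores in this assay, a 1.1-fold lower number (0.05 log units; within the scatter) from compound 1 to compound 2 and no change at the digits printed (within the scatter) from compound 3 to compound 4, 1.1-fold (0.05 log units) apart, within the scatter of two such steps

Among the compounds shown here, this agreement rests on only two pairs, and both steps are within the scatter, so it shows that the change is equally silent on these two cores, not that a step of real size would carry across them, and it gives no reason for the silence.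

Still open, from the compounds shown here alone, is whether any group at these places would move the number in this assay: an amine, a carboxylic acid or a benzyl group in place of the vinyl, on a saturated chain carbon bound to a saturated ring carbon, would test that. Also open, going by these compounds, is whether the agreement between the cores would hold for such groups, or for a read-out on another cell line.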